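Series notes: chain extension at the amide of compound 3

The source may hold more compounds than are shown below. What is called first, only, known or untested is meant among the compounds shown, and "the series" means these compounds.

Measured so far in a functional assay on M21 cells (Homo sapiens) for antiproliferative activity, read by sulforhodamine B assay, with a stated time of 48 h; a higher number here means a weaker inhibitor, a lower number a stronger inhibitor:
compound 1 `CC(C)c1ccccc1OS(=O)(=O)c1cccc(NC(=O)C(C)(C)C)c1` gives 13000 nM
compound 2 `CCC(=O)Nc1ccc(S(=O)(=O)Oc2ccccc2C(C)C)cc1` gives 11000 nM
compound 3 `CCC(=O)Nc1ccc(S(=O)(=O)Oc2ccccc2I)cc1` gives 11000 nM

Compound 3 stands level with compound 2 at the digits shown, the two together the lowest of the three numbers; compound 1 sits slightly higher, but that gap lies within the scatter, so no order among the three can be read. For the measured compounds named here, the one single-point step, no change at the digits printed from compound 2 to compound 3 (within the scatter), shows that exchanging one aromatic substituent for another left the number where it was. Compound 4 `CCCC(=O)Nc1ccc(S(=O)(=O)Oc2ccccc2I)cc1` differs from compound 3 by methyl in place of hydrogen on a saturated chain carbon, two bonds along the chain from a carbonyl carbon, that is, propanoyl to propylcarbonyl. Going by the values given here, no measured step touches the amide chain: compounds 1 and 2 differ in the chain but in a second place as well, and their values lie within the scatter of each other. With nothing pointing to a shift, compound 4 is expected to land near compound 3, with no change at the digits printed from compound 3 to compound 4 (within the scatter) meaning no step beyond the scatter. The estimate for compound 4 is 11000 nM, range 5000 nM to 25000 nM.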

Compound 4, half-maximal inhibitory concentration: 9000 nM
Compound 4: the middle estimate sits 1.2-fold (0.09 log units) above what was measured; measured number inside the range.
By their numbers in this assay, from the lowest: compounds 4, 2, 3 and 1 (each within the scatter of the next).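

In this assay, the step of a 1.2-fold lower number from compound 3 to compound 4 (0.09 log units; within the scatter) belongs to methyl in place of hydrogen on a saturated chain carbon, two bonds along the chain from a carbonyl carbon. For the compounds shown here, this is the first single-point reading on the amide chain, since compounds 1 and 2 differ in the chain but in a second place as well. Propanoyl to propylcarbonyl therefore leaves the number within the scatter on the core of compound 3.

Going by these compounds, whether a longer chain, or an amine or a carboxylic acid in place of the methyl, would move the number beyond the scatter stays open. Also open, on these data alone, is whether the same methyl change reads alike with isopropyl in place of iodo.

No measurement shown bears on this result.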